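The source may hold more compounds than are shown below. What is called first, only, known or untested is meant among the compounds shown, and "the series" means these compounds.

Measured compounds:
compound 1 `Cc1cc(-c2ccc(Cl)cc2)n(-c2ccc(S(N)(=O)=O)cc2)n1` with 49.8%
compound 2 `Cc1cc(-c2ccc(Cl)cc2)n(-c2ccc(S(=O)(=O)Nc3nccs3)cc2)n1` with 44.3%
compound 3 `Cc1cc(C)n(Cc2n[nH]c(=S)o2)n1` with 21.5%

In a functional assay on the whole organism (strain albino) for inhibition, with Rattus norvegicus as the target, read by paw edema, with stated times of 2 h and 1 h, at a dose of 100 mg/kg by the oral route (on this read-out higher numbers stand for more inhibition at the one dose given (going by the name of the read-out) and lower numbers for less inhibition), compound 3 stands lowest of the three measured numbers: compound 2 lies above it by an amount beyond the scatter, and compound 1 lies further above it, also beyond the scatter. The step to compound 4 `Cc1cc(-c2ccccc2)n(Cc2n[nH]c(=S)o2)n1` is phenyl in place of methyl on an aromatic carbon. Among the compounds with values here, the only measured step, a number 5.5 percentage points lower from compound 1 to compound 2 (within the scatter), concerns a different change on a different part of the shared core and lies within the scatter, so it does not bear directly on the change from compound 3 to compound 4. Compounds 1 and 2 carry an aryl group on the five-membered ring, and both give higher numbers than compound 3, but they differ from compound 3 in several other places as well, so their values show only what they show. Without a bearing step, compound 4 is estimated at 30%, within 15% to 45%, which is expected to mean a step of a number 8.5 percentage points higher from compound 3 to compound 4 (within the scatter) in this assay, likely not clearly beyond the scatter.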

Compound 4, a percentage reported as inhibition, in the whole organism at one dose (the size of the read-out at that dose, not a potency): 34.2%
The estimate for compound 4 lay 4.2 percentage points below the measured number; the range from low to high includes it.
By their numbers in this assay, from the lowest: compound 3; then compound 4; then compounds 2 and 1 (each within the scatter of the next).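

In this assay, phenyl in place of methyl on this aromatic carbon, next to the ring nitrogen, gives a number 12.7 percentage points higher from compound 3 to compound 4 (beyond the scatter). This is the first step shown at this position, and it shows that the number here responds to the group placed on this carbon, whereas the one earlier step concerned a sulfonamide nitrogen elsewhere and stayed within the scatter. Nothing available accounts for why the number rises with this change.

The compounds shown leave open how other groups would read on this same carbon, such as an amine, a carboxylic acid or a longer alkyl chain, so one step cannot show a trend with group size or type. As far as these compounds go, it also remains open whether the same change would have a similar effect on the ring atom that bears a methyl group in compound 4.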